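Benzoyl ring substitution on the shared core: writhing notes

This account rests on a few compounds, and the source may have more. Where it says the series, first, only, none or still open, it means among the compounds named here.

Measured compounds:
compound 1 `O=C(/N=C1\NC2(CCCCO2)CCS1)c1ccccc1` gives 5 mg/kg
compound 2 `O=C(/N=C1\NC2(CCCCO2)CCS1)c1ccc(F)cc1` gives 8.8 mg/kg; 28 mg/kg; 49 mg/kg (3 entries)
compound 3 `O=C(/N=C1\NC2(CCCCO2)CCS1)c1ccccc1Cl` gives > 200 mg/kg

In a functional assay on the whole organism (strain CF-1) with Mus musculus as the target, in the writhing test, with a stated time of 15 min (on this read-out lower numbers stand for an effect already at smaller amounts and higher numbers for an effect only at larger amounts of compound), compound 1 gives 5 mg/kg. Compound 2 has three entries in this assay, 8.8 mg/kg; 28 mg/kg; 49 mg/kg (3 entries); the spread is seen in the several entries of compound 2 in this assay, 8.8 mg/kg; 28 mg/kg; 49 mg/kg (3 entries). For compound 3 only a limit is known in this assay, > 200 mg/kg, which is the limit of > 200 mg/kg in this assay, at which 1 of the 3 values shown sits. Compound 3 therefore stands at the limit, with no single number.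

For the measured compounds named here, the only measured step that bears on the next change is an at least 40-fold higher number from compound 1 to compound 3 (1.60 log units; beyond the scatter). The unmeasured compound 4 `Cc1ccc(C(=O)/N=C2\NC3(CCCCO3)CCS2)cc1` differs from compound 3 by 4-methylphenyl in place of 2-chlorophenyl on a carbonyl carbon. The change removes the chloro whose entry gave the large step and puts a methyl on the ring in the manner of the fluoro of compound 2, which sits near compound 1. A large step back toward compound 1 and compound 2 is therefore expected, with the number for compound 4 estimated at 15 mg/kg, range 4 mg/kg to 60 mg/kg. The expected step is an at least 13-fold lower number from compound 3 to compound 4 (1.12 log units; beyond the scatter).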

Compound 4, dose for half-maximal effect: 60 mg/kg
Compound 4: the middle estimate sits 4.0-fold (0.60 log units) below what was measured, and the stated range covers the measured number.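

As far as these compounds go, replacing 2-chlorophenyl with 4-methylphenyl on a carbonyl carbon gives an at least 3.3-fold lower number from compound 3 to compound 4 (0.52 log units; beyond the scatter) in this assay, so a single number returns, although the size of this step stays open-ended as it rests on a limit: the limit of > 200 mg/kg in this assay, at which 1 of the 4 values shown sits. A substituent on this ring still carries a cost, since methyl in place of hydrogen gives a 12-fold higher number from compound 1 to compound 4 (1.08 log units; beyond the scatter). Compound 2 gives no single number to set beside this step: the several entries of compound 2 in this assay, 8.8 mg/kg; 28 mg/kg; 49 mg/kg (3 entries).

From the compounds shown here alone, the step from compound 3 changes both the group and its place on the ring, so the share of each remains open. Also open, going by these compounds, is how the ring would read in this assay with an amine, a carboxylic acid or a longer chain in place of the methyl.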